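Replacing a trifluoromethylphenyl amine with an ethoxyphenyl amine

A few compounds are considered here, and "the series" means these few. Any claim that something is new, unique, unknown or untested is made for them only; others in the source may bear on it.

Compound 1 `FC(F)(F)c1ccc(CSc2nc(Nc3cccc(C(F)(F)F)c3)c3ccccc3n2)cc1` was tested in a functional assay on PC-3 cells (Homo sapiens) for cytotoxicity, read by MTT assay, with a stated time of 72 h (a higher number here means a weaker inhibitor, a lower number a stronger inhibitor), where compound 1 gives 12900 nM. Among the three measured compounds it holds the second highest number; its nearest neighbour is compound 3 `COc1ccc(Nc2nc(SCc3ccc(C(F)(F)F)cc3)nc3ccccc23)cc1`, which in this assay gives 16700 nM, and the one furthest from it is compound 2 `FC(F)(F)c1ccc(CSc2nc(Nc3ccc(Cl)cc3)c3ccccc3n2)cc1`, which in this assay gives 7110 nM. The step of a 1.8-fold lower number from compound 1 to compound 2 (0.26 log units; within the scatter) and the step of a 1.3-fold higher number from compound 1 to compound 3 (0.11 log units; within the scatter) both stay within the scatter, while the step of a 2.3-fold higher number from compound 2 to compound 3 (0.37 log units; beyond the scatter) is a modest one beyond it.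

Compound 4 `CCOc1ccc(Nc2nc(SCc3ccc(C(F)(F)F)cc3)nc3ccccc23)cc1` has not yet been measured in this assay. It differs from compound 1 in one place: 4-ethoxyphenyl in place of 3-(trifluoromethyl)phenyl on a nitrogen on an aromatic ring. Among the measured compounds shown here, the closest precedent is compound 3, because its step of a 1.3-fold higher number from compound 1 to compound 3 (0.11 log units; within the scatter) shows that a 4-methoxyphenyl on this nitrogen leaves the number essentially where compound 1 stands. An ethoxy group is expected to behave much like that, so no step beyond the scatter is expected, with the number expected to sit near compound 3. Compound 4 is therefore estimated to give 15000 nM in this assay, in the range 7000 nM to 33000 nM; this estimate amounts to the step of a 1.2-fold higher number from compound 1 to compound 4 (0.07 log units; within the scatter).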

Compound 4, half-maximal inhibitory concentration: 32100 nM
Estimate against measurement, compound 4: 2.1-fold (0.33 log units) below; the measured number falls inside the stated range.
By their numbers in this assay, from the lowest: compounds 2, 1, 3 and 4 (each within the scatter of the next, the first and the last beyond it).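

In this assay, the 4-ethoxyphenyl on this nitrogen gives a 2.5-fold higher number from compound 1 to compound 4 (0.40 log units; beyond the scatter), the first step away from the 3-(trifluoromethyl)phenyl of compound 1 that lies beyond the scatter. The extra methyl on the alkoxy chain does not by itself separate the two alkoxy groups, at a 1.9-fold higher number from compound 3 to compound 4 (0.28 log units; within the scatter), whereas ethoxy in place of chloro gives a 4.5-fold higher number from compound 2 to compound 4 (0.65 log units; beyond the scatter), so the 4-chlorophenyl and 4-ethoxyphenyl groups are the clearest contrast at this nitrogen so far. Nothing available here accounts for these differences.

On these data alone, it remains open whether a propoxy or a hydroxy group in place of the ethoxy would move the number further in either direction. Also unresolved is how much of the step from compound 1 comes from the change of group and how much from where that group sits on the phenyl ring.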